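Swapping the aryl group on the pyrazole nitrogen

The source may report more compounds than this note shows. Statements on the series, on what has been measured and on what is new or still open speak of the compounds shown alone.

Measured compounds:
Compound 1 `COc1cccc(-n2cc(NC(=O)c3cccc(NS(=O)(=O)c4ccccc4)c3)cn2)c1` gives 26200 nM in a functional assay on HeLa cells (Homo sapiens) for inhibition, read by MTT assay, with a stated time of 48 h; a lower number here means a stronger inhibitor, a higher number a weaker inhibitor.
Compound 2 `Cc1ccc(-n2cc(NC(=O)c3cccc(NS(=O)(=O)c4ccc(Cl)cc4)c3)cn2)cc1` gives 4570 nM in this assay.

Of these two numbers, compound 2 has the lower one, and the gap to compound 1 lies beyond the scatter of the method. The two compounds differ in two places at once, so no single change can be tied to that gap.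

Compound 3 `COc1cccc(-n2cc(NC(=O)c3cccc(NS(=O)(=O)c4ccc(Cl)cc4)c3)cn2)c1` keeps the sulfonyl part of compound 2 and changes only the group on the ring nitrogen: 3-methoxyphenyl in place of 4-methylphenyl on an aromatic nitrogen. Within the data shown here, the group that enters is the one carried by compound 1, and the sulfonyl part is the one carried by compound 2, so compound 3 sits between the two measured structures. Among the measured compounds shown here, no measured pair isolates this change. The step of a 2.2-fold higher number from compound 2 to compound 3 (0.34 log units; beyond the scatter) is expected to be a moderate rise in the number, with wide uncertainty. Compound 3 is estimated at 10000 nM, in a range from 3000 nM to 35000 nM.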

Compound 3, half-maximal inhibitory concentration: 25000 nM
Compound 3: the middle estimate sits 2.5-fold (0.40 log units) below what was measured; the range from low to high includes it.
By their numbers in this assay, from the lowest: compound 2; then compounds 3 and 1 (each within the scatter of the next).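

In this assay, among these compounds, putting 3-methoxyphenyl in place of 4-methylphenyl on the ring nitrogen gives a 5.5-fold higher number from compound 2 to compound 3 (0.74 log units; beyond the scatter), the first reading of this position with only one thing changed. Adding chloro in place of hydrogen on an aromatic carbon, with 3-methoxyphenyl on the nitrogen, gives a 1.0-fold lower number from compound 1 to compound 3 (0.02 log units; within the scatter), so of these two single changes only the one on the ring nitrogen lies beyond the scatter. Nothing measured here explains why the group on the nitrogen matters in this pair.

The compounds shown leave open whether chloro would make as little difference with 4-methylphenyl on the nitrogen. They also leave open how a plain phenyl group or a short chain such as ethyl would read at this position.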